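A few compounds are considered here, and "the series" means these few. Any claim that something is new, unique, unknown or untested is made for them only; others in the source may bear on it.

Compound 1 `CCCSc1nc(N/N=C(\C)c2ccc(O)cc2)c2nnn(Cc3ccccc3)c2n1` is measured in a functional assay on MCF7 cells (Homo sapiens) for antiproliferative activity, read by MTT assay, with a stated time of 72 h (on this read-out lower numbers stand for stronger inhibition and higher numbers for weaker inhibition), where it gives 21600 nM. Where compound 1 stands can only be said loosely, since it carries the one real number of the two values shown, the other being a limit. Compound 2 `C#CCSc1nc(N/N=C/c2ccc(N(C)C)cc2)c2nnn(Cc3ccccc3)c2n1` reaches only the limit of > 64000 nM in this assay. That one of the two values sits at the limit of > 64000 nM in this assay, at which 1 of the 2 values shown sits, marks the weak end of this small set.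

Compound 3 `CCCSc1nc(N/N=C/c2ccc(Br)cc2)c2nnn(Cc3ccccc3)c2n1` has not yet been measured in this assay. It differs from compound 1 in one place: a group of 9 heavy atoms (7 carbon, 1 nitrogen, 1 bromine; one six-membered aromatic ring of carbon only) in place of a group of 10 heavy atoms (8 carbon, 1 nitrogen, 1 oxygen; one six-membered aromatic ring of carbon only), on a nitrogen on an aromatic ring. Going by the values given here, no measured step between two compounds exists here, so the size of this change can only be guessed. The expectation is a step from compound 1 to compound 3 of a 1.1-fold lower number from compound 1 to compound 3 (0.03 log units; within the scatter), a shift within the usual scatter. Compound 3 is therefore estimated at 20000 nM, with a range from 6000 nM to 64000 nM.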

Compound 3, half-maximal inhibitory concentration: > 64000 nM
Compound 3: no number, only a limit; the forecaster's own chance of this, stated with the estimate: 30%; middle value at least 3.2-fold (0.50 log units) from the limit.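

In this assay, going by these compounds alone, the group on this nitrogen clearly matters: replacing the one in compound 1 with the bromine-bearing group gives an at least 2.9-fold higher number from compound 1 to compound 3 (0.47 log units; beyond the scatter). On these data alone, compound 3 gives > 64000 nM, which is a limit and not a number, so the true size of the step stays unknown and compound 3 joins the weak end of the set: the limit of > 64000 nM in this assay, at which 2 of the 3 values shown sit. The change is also more than one atom, since the leaving group has 10 heavy atoms, including an oxygen, and 1 hydrogen-bond donor, while the entering group has 9 heavy atoms, including a bromine, and 0 hydrogen-bond donors.

The compounds shown leave open whether losing the oxygen, gaining the bromine or losing the extra carbon drives this step. They also leave open how a methoxy group, a chlorine or a carboxylic acid would read in place of the bromine.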